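The source may report more compounds than this note shows. Statements on the series, on what has been measured and on what is new or still open speak of the compounds shown alone.

In an assay on HEK293 cells for displacement of a labelled ligand from D(3) dopamine receptor (Rattus norvegicus) (on this read-out higher numbers stand for weaker inhibition and lower numbers for stronger inhibition), three compounds have been measured so far:
compound 1 `CCCN(CCN1CCN(c2ccc(-c3ccc(OC)cc3)cc2)CC1)C1CCc2nc(N)sc2C1` gives 1.41 nM
compound 2 `CCCN(CCN1CCN(c2ccc(-c3cccc(OC)c3)cc2)CC1)C1CCc2nc(N)sc2C1` gives 2.11 nM
compound 3 `CCCN(CCN1CCN(c2ccc(-c3ccccc3OC)cc2)CC1)C1CCc2nc(N)sc2C1` gives 3.57 nM

Compound 3 stands highest of these three numbers. The nearest number is that of compound 2, and that step, a 1.7-fold higher number from compound 2 to compound 3 (0.23 log units; within the scatter), remains within the scatter, while a 2.5-fold higher number from compound 1 to compound 3 (0.40 log units; beyond the scatter) is a modest step beyond it. Compound 4 `CCCN(CCN1CCN(c2ccc(-c3ccc(O)cc3)cc2)CC1)C1CCc2nc(N)sc2C1` has not yet been measured; it differs from compound 3 by 4-hydroxyphenyl in place of 2-methoxyphenyl on an aromatic carbon. Two parts of this change can be separated. The oxygen returns to the position it occupies in compound 1, para to a large group, and the step in the opposite direction, a 2.5-fold higher number from compound 1 to compound 3 (0.40 log units; beyond the scatter), was modest, so this part alone would be expected to bring the number down again. For the measured compounds named here, the exchange of a methoxy group for a hydroxyl group has no counterpart among the measured compounds, and nothing here tells its size or direction. On that basis compound 4 is expected to give about 1.8 nM in this assay, within a range from 0.7 nM to 5 nM. The expected step is therefore a 2.0-fold lower number from compound 3 to compound 4 (0.30 log units; within the scatter).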

Compound 4, inhibition constant: 1.17 nM
The estimate for compound 4 lay 1.5-fold (0.19 log units) above the measured number; measured number inside the range.
By their numbers in this assay, from the lowest: compounds 4, 1, 2 and 3 (each within the scatter of the next, the first and the last beyond it).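

Hydrogen in place of methyl on the oxygen can now be read directly, and in this assay it gives a 1.2-fold lower number from compound 1 to compound 4 (0.08 log units; within the scatter), so the 4-hydroxyphenyl and 4-methoxyphenyl groups are not told apart at this position. Compared with the other two methoxy compounds, a 1.8-fold lower number from compound 2 to compound 4 (0.26 log units; within the scatter) also leaves that pair unseparated, whereas a 3.1-fold lower number from compound 3 to compound 4 (0.48 log units; beyond the scatter) is a modest step, so compound 3 stands apart from compound 4 as it does from compound 1. No evidence is available on what lies behind these numbers.

The compounds shown leave open whether 3-hydroxyphenyl or 2-hydroxyphenyl would match their methoxy counterparts. They also leave open whether an amine, a carboxylic acid or a longer chain such as ethoxy in place of the hydroxyl would keep the number level with compound 1.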